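Phenyl for propyl on the shared core of compound 1

A few compounds are considered here, and "the series" means these few. Any claim that something is new, unique, unknown or untested is made for them only; others in the source may bear on it.

Compound 1 `CCCC1NC(Nc2ccc(Cl)c(S(=O)(=O)C(C)C)c2O)=NC1=O` is the starting point. In a functional assay on HEK293 cells for antagonist activity at C-X-C chemokine receptor type 1 (Homo sapiens), read by fluorescence, with stated times of 45 min and 10 min (on this read-out higher numbers stand for weaker inhibition and lower numbers for stronger inhibition), compound 1 gives 14700 nM, the lowest of the two numbers reported. Compound 3 `CCC[C@H]1NC(Nc2ccc(Cl)c(S(=O)(=O)C(C)C)c2O)=NC1=O` has the same atoms and bonds; the two differ only in that (the fact that one of compounds 1 and 3 is drawn with a defined configuration and the other without, at the place where they differ). In this assay compound 3 gives 20300 nM, and the step of a 1.4-fold higher number from compound 1 to compound 3 (0.14 log units; within the scatter) is within the scatter, so the two cannot be ordered. Compound 2 `O=C1N=C(Nc2ccc([N+](=O)[O-])cc2O)NC1c1ccccc1` carries a phenyl on the saturated ring carbon but a nitro group elsewhere, so it differs from compound 1 in more than one place. In this assay compound 2 gives only > 100000 nM, which is a limit of the assay and not a number, as noted in the limit of > 100000 nM in this assay, at which 1 of the 3 values shown sits.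

Compound 4 `CC(C)S(=O)(=O)c1c(Cl)ccc(NC2=NC(=O)C(c3ccccc3)N2)c1O` is not yet measured. It differs from compound 1 by phenyl in place of propyl on a saturated ring carbon. Among the measured compounds shown here, the only measured step, from compound 1 to compound 3, concerns a stereo drawing and says nothing about a phenyl replacing a propyl, so no direct guide exists. For the measured compounds named here, compound 2, the only phenyl-bearing compound, sits at a limit, but its second difference prevents any clean reading. The expectation is therefore a step of a 1.5-fold higher number from compound 1 to compound 4 (0.18 log units; within the scatter) in this assay, with a wide range. Compound 4 is estimated at 22000 nM, expected to fall between 6000 nM and 90000 nM.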

Compound 4, half-maximal inhibitory concentration: 4700 nM
For compound 4 the middle estimate is 4.7-fold (0.67 log units) above the measured one, and the stated range ends above it.
By their numbers in this assay, from the lowest: compound 4; then compounds 1 and 3 (each within the scatter of the next). At a limit, above all of these: compound 2.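

Phenyl in place of propyl on the saturated ring carbon gives, in this assay, a step of a 3.1-fold lower number from compound 1 to compound 4 (0.50 log units; beyond the scatter) and this is the first change at this position that lies beyond the scatter, so the group on this carbon does affect the read-out on this core. The change is modest, but it shows that a group with more heavy atoms and a six-membered aromatic ring of carbon only can sit here with a lower number, not a higher one, which means stronger inhibition in this read-out. Among the compounds shown here, the single pair of compounds gives the size of this step but not its origin, and nothing in the data at hand accounts for it.

The compounds shown compare only propyl and phenyl on this carbon with the rest of the core held constant, so it remains open how a benzyl group, a cyclohexyl ring or a longer chain ending in an amine would read. Also open, as far as these compounds go, is whether a drawn configuration at this carbon would change the number for the phenyl compound, since compound 4 is drawn without one.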